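Working notes: compound 3 set against compound 2

This account rests on a few compounds, and the source may have more. Where it says the series, first, only, none or still open, it means among the compounds named here.

In a functional assay on HCT-116 cells (Homo sapiens) for cytotoxicity (a lower number here means a stronger inhibitor, a higher number a weaker inhibitor), two compounds on a shared core have been measured. Compound 1 (`O=C1NC(=O)c2c1c1c3ccc(CN4CCCC4)cc3[nH]c1c1c2c2cccc3c2n1CCC3`) gives 170 nM. Compound 2 (`O=C1NC(=O)c2c1c1c3ccc(-c4cccnc4)cc3[nH]c1c1c2c2cccc3c2n1CCC3`) gives 1130 nM, the higher of the two numbers, which makes it the weaker inhibitor of the pair.

Compound 3 (`O=C1NC(=O)c2c1c1c3ccc(CN4CCCCC4)cc3[nH]c1c1c2c2cccc3c2n1CCC3`) has not yet been measured. Its change from compound 2 is (piperidin-1-yl)methyl in place of pyridin-3-yl on an aromatic carbon. In short, (piperidin-1-yl)methyl stands in place of pyridin-3-yl on an aromatic carbon.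

Among the measured compounds shown here, only one measured step bears on this change. The step of a 6.6-fold higher number from compound 1 to compound 2 (0.82 log units; beyond the scatter) is modest but beyond the scatter, and it exchanges (pyrrolidin-1-yl)methyl for pyridin-3-yl at the same place. The group entering compound 3 is a close relative of the (pyrrolidin-1-yl)methyl of compound 1, so a step of similar size is expected, in the opposite direction, towards a lower number. For the measured compounds named here, no measured compound yet carries (piperidin-1-yl)methyl, so the range stays wide. The expected change is a 5.7-fold lower number from compound 2 to compound 3 (0.75 log units; beyond the scatter). For compound 3 the estimate is 200 nM, with an estimated range of 80 nM to 500 nM.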

Compound 3, half-maximal inhibitory concentration: 320 nM
Compound 3: middle estimate off by 1.6-fold (0.20 log units), on the low side; low and high end bracket the measured number.
By their numbers in this assay, from the lowest: compounds 1 and 3 (each within the scatter of the next); then compound 2.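

In this assay, placing (piperidin-1-yl)methyl on the aromatic carbon in place of pyridin-3-yl gives a 3.5-fold lower number from compound 2 to compound 3 (0.55 log units; beyond the scatter), so the lower number is no longer tied to the single (pyrrolidin-1-yl)methyl group of compound 1; among the three compounds, both saturated-ring groups sit lower than pyridin-3-yl, and none goes against this. Exchanging the ring on the saturated chain carbon gives a 1.9-fold higher number from compound 1 to compound 3 (0.27 log units; within the scatter), so this assay does not separate piperidin-1-yl from pyrrolidin-1-yl, and this ring change shows no measurable preference here. Nothing available explains why these two groups differ from pyridin-3-yl.

The compounds shown leave open whether the ring itself matters, since an open-chain dimethylaminomethyl group, a morpholin-4-ylmethyl group or a piperidine ring bound directly to the aromatic carbon would each test a different part of the group. They also leave open how the linking carbon contributes, which a longer chain between the ring nitrogen and the aromatic carbon would address, and whether a plain phenyl group would sit with pyridin-3-yl.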